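Moving the Chlorine on the Pendant Phenyl of Compound 1

A few compounds are considered here, and "the series" means these few. Any claim that something is new, unique, unknown or untested is made for them only; others in the source may bear on it.

Compound 1 `O=S(=O)(c1ccc(F)c(F)c1)c1cnc2c(F)cccc2c1-c1ccc(Cl)cc1` has been tested in an ADME assay on microsomes from liver (Homo sapiens) for metabolic stability, tested at 2.5 uM (a lower number here means slower removal, a higher number faster removal of the compound), where compound 1 gives 0.28 mL/min. That is the lowest of the three numbers measured: compound 3 `O=S(=O)(c1cccc(F)c1)c1cnc2c(F)cccc2c1-c1ccc(Cl)cc1` gives 0.62 mL/min, a step of a 2.2-fold higher number from compound 1 to compound 3 (0.35 log units; beyond the scatter), and compound 2 `Cc1ccc(S(=O)(=O)c2cnc3c(F)cccc3c2-c2ccc(Cl)cc2)cc1F` gives 2.2 mL/min, a step of a 7.9-fold higher number from compound 1 to compound 2 (0.90 log units; beyond the scatter). Between those two, a 3.5-fold lower number from compound 2 to compound 3 (0.55 log units; beyond the scatter). Compound 4 `O=S(=O)(c1ccc(F)c(F)c1)c1cnc2c(F)cccc2c1-c1cccc(Cl)c1` differs from compound 1 only in 3-chlorophenyl in place of 4-chlorophenyl on an aromatic carbon. For the measured compounds named here, none of the measured steps touches that ring; all three concern a different part of the shared core, where fluoro, methyl and hydrogen are exchanged. Going by the values given here, no measured step therefore bears on this change, and no movement beyond the scatter is expected in this assay. For compound 4 the expected value is 0.3 mL/min, with a range of 0.14 mL/min to 0.7 mL/min, the expected step being a 1.1-fold higher number from compound 1 to compound 4 (0.03 log units; within the scatter).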

Compound 4, intrinsic clearance in a liver preparation (reported as CLH), per the amount of preparation that the assay uses: 1.13 mL/min
For compound 4 the middle estimate is 3.8-fold (0.58 log units) below the measured one; the whole stated range lies below it.
By their numbers in this assay, from the lowest: compound 1; then compounds 3, 4 and 2 (each within the scatter of the next, the first and the last beyond it).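

Moving the chlorine, with the same atoms simply joined differently, gives a 4.0-fold higher number from compound 1 to compound 4 (0.61 log units; beyond the scatter) in this assay. For the compounds shown here, the earlier steps exchanged only fluoro, methyl and hydrogen elsewhere on the shared core, so this is the first sign that the chlorine's place on the pendant phenyl matters in this read-out. Nothing shown accounts for this shift.

On these data alone, it remains open whether a nitrile or a methoxy group in place of the chlorine of 3-chlorophenyl would stay near compound 4 or return towards compound 1. As far as these compounds go, the same move of the chlorine on compound 3 is also open.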